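Aryl swap on the thiourea of a weakly active core

The source may hold more compounds than are shown below. What is called first, only, known or untested is meant among the compounds shown, and "the series" means these compounds.

Among the compounds with values here, compound 2 `CSc1ccccc1NC(=S)N1CCc2c(sc(NC(=O)c3ccccc3Cl)c2C(N)=O)C1` is the only compound with a number in a functional assay on HeLa cells (Homo sapiens) for antiproliferative activity, with a stated time of 24 h (a higher number here means a weaker inhibitor, a lower number a stronger inhibitor), where compound 2 gives 43600 nM. Compound 1 `NC(=O)c1c(NC(=O)c2ccccc2Cl)sc2c1CCN(Cc1ccc(Cl)cc1)C2` reaches only a limit of the assay in this assay, at > 50000 nM, a limit noted as the limit of > 50000 nM in this assay, at which 1 of the 2 values shown sits. Within the data shown here, the one measured step, an at least 1.1-fold lower number from compound 1 to compound 2 (0.05 log units; that floor lies within the scatter), sits at a different place, on an amine nitrogen in a ring, and its size is a floor that lies within the scatter. Compound 3 `NC(=O)c1c(NC(=O)c2ccccc2Cl)sc2c1CCN(C(=S)Nc1cccnc1)C2` differs from compound 2 by pyridin-3-yl in place of 2-(methylsulfanyl)phenyl on an amide-type nitrogen, a change on the thiourea side rather than the ring amine. Among the measured compounds shown here, the single measured step gives no guidance on the size of a change at this position, so no step beyond the scatter is expected in this assay. Compound 3 is therefore expected to give about 45000 nM in this assay, between 15000 nM and 120000 nM. The expected step of a 1.0-fold higher number from compound 2 to compound 3 (0.01 log units; within the scatter) is estimated to lie within the scatter, with a real chance that only a limit is reported.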

Compound 3, half-maximal inhibitory concentration: > 50000 nM
Compound 3: no number, only a limit (the forecaster's own chance of this, stated with the estimate: 45%); middle value at least 1.1-fold (0.04 log units) from the limit.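

From the compounds shown here alone, the swap of 2-(methylsulfanyl)phenyl for pyridin-3-yl on the amide-type nitrogen gives an at least 1.1-fold higher number from compound 2 to compound 3 (0.05 log units; that floor lies within the scatter), so this first reading on the thiourea side shows no change beyond the scatter, and its true size stays unknown. Within the data shown here, compound 3 gives only a limit of the assay in this assay, which leaves compound 2 as the only compound with a number: the limit of > 50000 nM in this assay, at which 2 of the 3 values shown sit. The steps that join two limits cannot be read, so the change on the ring amine gains nothing from this result.

Going by these compounds, it remains open whether a phenyl group carrying an amine or a carboxylic acid on the amide-type nitrogen would give a number clearly beyond the scatter. Also open, on these data alone, is what a urea carbonyl would do in place of the thiocarbonyl.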